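The source may hold more compounds than are shown below. What is called first, only, known or untested is meant among the compounds shown, and "the series" means these compounds.

In a functional assay on C6 cells (Rattus norvegicus) for cytotoxicity, read by CellTiter-Glo, with a stated time of 72 h (a higher number here means a weaker inhibitor, a lower number a stronger inhibitor), compound 1 `C=C1C(=O)C2=C3[C@@H](CC[C@H]4C(=C)C(=O)O[C@@H]4[C@@H]13)CC[C@]21C(=O)C[C@H]2C(=C)CC[C@H]3C(=C)C(=O)O[C@@H]3[C@H]21` gives 6400 nM, the higher of the two actual numbers in the series. Compound 3 `C=C1C(=O)C2=C3[C@H](CC[C@H]4C(=C)C(=O)O[C@@H]4[C@@H]13)CC[C@@]21C(=O)C2=C3[C@H]1[C@H]1OC(=O)C(=C)[C@@H]1CC[C@@]3(O)CC[C@]21C(=O)C[C@H]2C(=C)CC[C@H]3C(=C)C(=O)O[C@@H]3[C@H]21` gives 2100 nM, a lower number by a margin beyond the usual scatter. Compound 2 `C=C1C(=O)O[C@@H]2[C@@H]3C4=C(C(=O)[C@H]3CO)[C@]3(CC[C@]4(O)CC[C@@H]12)C(=O)C[C@H]1C(=C)CC[C@H]2C(=C)C(=O)O[C@@H]2[C@H]13` reached only a limit of the assay, > 10000 nM, so it has no exact value to set beside the others.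

Compound 4 `C=C1C(=O)C2=C3[C@H]1[C@H]1OC(=O)C(=C)[C@@H]1CC[C@]3(O)CC[C@]21C(=O)C[C@H]2C(=C)CC[C@H]3C(=C)C(=O)O[C@@H]3[C@H]21` has not yet been measured. It differs from compound 1 by a single change: hydroxy in place of hydrogen on a saturated ring carbon. A hydroxy group thus replaces hydrogen on a saturated ring carbon, and the rest of the core of compound 1 is unchanged. Within the data shown here, no measured pair isolates this change, so its effect has not been observed directly.

Compound 2 and compound 3 also carry a hydroxy group, but they give no common direction. Compound 3 sits at 2100 nM. Compound 2 stands at the limit. No step beyond the scatter is therefore expected in this assay, and the expected move is small, a 1.1-fold lower number from compound 1 to compound 4 (0.03 log units; within the scatter). For compound 4 the estimated value is 6000 nM, with an expected range from 2500 nM to 14000 nM.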

Compound 4, half-maximal inhibitory concentration: 1200 nM
Compound 4: middle estimate off by 5.0-fold (0.70 log units), on the high side; measured number outside the range, below it.
By their numbers in this assay, from the lowest: compounds 4 and 3 (each within the scatter of the next); then compound 1. At a limit, above all of these: compound 2.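

In this assay, among these compounds, hydroxy in place of hydrogen on a saturated ring carbon gives a 5.3-fold lower number from compound 1 to compound 4 (0.73 log units; beyond the scatter), the first direct reading of this change. The position, on a six-membered non-aromatic ring of carbon only and next to the ring atom that bears a fused ring, therefore takes a hydroxy group with a clear drop in the number rather than a loss of activity, something that compound 2 and compound 3 could not show, as neither differs from compound 1 in this one place alone. Nothing in the data shown accounts for the size of this step.

From the compounds shown here alone, it remains open whether the hydroxy group itself is what matters at this ring carbon, or whether a methoxy group, an amine or a fluorine atom in the same place would move the number in the same way. Also open, going by these compounds, are the effect of the hydroxy group with the opposite configuration at this carbon and whether the step holds in cells other than those of this assay.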